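Metabolic stability notes: N-methyl to N-H on the core

This account rests on a few compounds, and the source may have more. Where it says the series, first, only, none or still open, it means among the compounds named here.

Measured so far:
compound 1, `CN(C[C@H]1Cc2c(cccc2N2C[C@@H]3C[C@H]2CN3)CN1)[C@H]1CCCc2cccnc21`: 100%
compound 2, `CC(C)N1CCN(c2cccc3c2C[C@H](CN(C)[C@H]2CCCc4cccnc42)NC3)CC1`: 56.6%
compound 3, `CN1CCN(c2cccc3c2C[C@H](CN(C)[C@H]2CCCc4cccnc42)N(C)C3)CC1`: 83.3%

In an ADME assay on microsomes from liver (Homo sapiens) for metabolic stability, read by LC-MS, with a stated time of 10 min (a lower number here means that less of the compound is left, a higher number that more of the compound is left), compound 1 gives 100% and compound 2 gives 56.6%. Among the measured compounds shown here, the one step that joins two measured compounds in a single change runs a number 43.4 percentage points lower from compound 1 to compound 2 (beyond the scatter). Compound 3 gives 83.3% and stands second highest of the three numbers, beyond the scatter from both compound 1 and compound 2.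

The next compound is compound 4, `CN1CCN(c2cccc3c2C[C@H](CN(C)[C@H]2CCCc4cccnc42)NC3)CC1`. It differs from compound 3 only as hydrogen in place of methyl on an amine nitrogen in a ring.

For the measured compounds named here, no measured pair isolates this change. The step from compound 1 to compound 2 concerns the group on the aromatic carbon, not the amine nitrogen in the ring, so it does not bear on it. Going by the values given here, compound 2 and compound 3 differ in two places at once and show only that both numbers lie below compound 1.

Among the compounds with values here, with no direct precedent, the expectation for compound 4 in this assay is a step of a number 3.3 percentage points lower from compound 3 to compound 4 (within the scatter), within the scatter in either direction. Compound 4 is therefore estimated at 80%, with a range from 60% to 100%.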

Compound 4, percent of the compound remaining: 75.8%
Compound 4: middle estimate off by 4.2 percentage points, on the high side; the range from low to high includes it.
By their numbers in this assay, from the lowest: compound 2; then compounds 4 and 3 (each within the scatter of the next); then compound 1.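

In this assay, among the compounds shown here, the step of a number 7.5 percentage points lower from compound 3 to compound 4 (within the scatter) is the first direct reading of hydrogen in place of methyl on this amine nitrogen in a ring, and it does not separate the two compounds. Compound 4 also links this series to the other two compounds through single changes elsewhere: methyl in place of isopropyl on an amine nitrogen in a ring gives a number 19.2 percentage points higher from compound 2 to compound 4 (beyond the scatter), and exchanging the group on the aromatic carbon gives a number 24.2 percentage points lower from compound 1 to compound 4 (beyond the scatter). Among these three steps, only the two changes away from the core nitrogen lie beyond the scatter, so in this small set the core nitrogen is the one place where a change leaves no readable difference. No measurement shown here accounts for any of these steps.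

From the compounds shown here alone, whether an ethyl or acetyl group on this amine nitrogen would read like methyl and hydrogen remains open. Also open is whether hydrogen and methyl at this place would stay within the scatter with the groups on the aromatic carbon of compound 1 or compound 2, since each of those is shown only with hydrogen there.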